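The source may hold more compounds than are shown below. What is called first, only, known or untested is meant among the compounds shown, and "the series" means these compounds.

Compound 2 `O=C(C1CCCC1)N1CCc2nc(C#Cc3ccccc3)sc2C1` is read in an assay on HEK293 cells for negative allosteric modulation of metabotropic glutamate receptor 5 (Homo sapiens), read by FLIPR, with a stated time of 1 h (on this read-out higher numbers stand for weaker inhibition and lower numbers for stronger inhibition), only as a limit, > 10000 nM. Compound 1 `CCN1CCc2nc(C#Cc3ccccc3)sc2C1` gives 1200 nM in this assay. Going by the values given here, the step of an at least 8.3-fold higher number from compound 1 to compound 2 (0.92 log units; beyond the scatter) is the sole measured step, and it concerns the amide rather than the ring on it; the limit of > 10000 nM in this assay, at which 1 of the 2 values shown sits, shows how far that step can be followed. Compound 3 `O=C(C1CCOCC1)N1CCc2nc(C#Cc3ccccc3)sc2C1` differs from compound 2 by oxan-4-yl in place of cyclopentyl on a carbonyl carbon. Among the compounds with values here, no measured step bears on this exchange, so in this assay no shift beyond the scatter is expected. Compound 3 is therefore estimated at 12000 nM, within 3000 nM to 40000 nM, an expected step that the limit leaves unreadable from compound 2 to compound 3.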

Compound 3, half-maximal inhibitory concentration: > 10000 nM
Compound 3: no number, only a limit (the forecaster's own chance of this, stated with the estimate: 70%); the middle value lies beyond the limit too.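

Compound 3 shows that the loss seen with the amide does not depend on cyclopentyl alone: with (oxan-4-yl)carbonyl in place of ethyl on the amine nitrogen in a ring there is an at least 8.3-fold higher number from compound 1 to compound 3 (0.92 log units; beyond the scatter). The step from compound 2 to compound 3 cannot be read, as both values are limits. Two different rings on the carbonyl carbon thus end at the same limit in this assay: the limit of > 10000 nM in this assay, at which 2 of the 3 values shown sit.

On these data alone, what stays open is how far the two amides lie past that limit. As far as these compounds go, it is also open whether a propyl chain or a benzyl group in place of ethyl, with no carbonyl, would give a lower number than compound 1.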